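Sulfamide-piperidine pyrimidines: ortho-halogen swap on the extended chain

The compounds below may be only part of what the source reports. "The series", "measured", "known", "first", "only" and "open" are said of these compounds alone.

Compound 1 `NS(=O)(=O)NCC1CCN(c2cc(-c3ccccc3Cl)ncn2)CC1` carries a chloro group on the pendant aromatic ring. In a functional assay on M21 cells (Homo sapiens) for antiproliferative activity, read by sulforhodamine B assay, with a stated time of 48 h (a lower number here means a stronger inhibitor of growth, a higher number a weaker inhibitor of growth), compound 1 gives only the limit > 100000 nM. Compound 2 `NS(=O)(=O)NCC1CCN(c2cc(-c3ccccc3F)ncn2)CC1` differs by fluoro in place of chloro on an aromatic carbon. In this assay compound 2 likewise gives only the limit > 100000 nM. The step that the two limits leave unreadable from compound 1 to compound 2 therefore cannot be sized. Going by the values given here, compound 3 `NS(=O)(=O)NCCC1CCN(c2cc(-c3ccccc3Cl)ncn2)CC1` differs from compound 1 in its core by (sulfamoylamino)methyl in place of sulfamoylamino on a saturated chain carbon bound to a saturated ring carbon, and in this assay compound 3 gives 93900 nM, the single number in the set; the step of an at least 1.0-fold lower number from compound 1 to compound 3 (0.02 log units; that floor lies within the scatter) is read against the limit (the limit of > 100000 nM in this assay, at which 2 of the 3 values shown sit).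

Compound 4 `NS(=O)(=O)NCCC1CCN(c2cc(-c3ccccc3F)ncn2)CC1` differs from compound 3 by fluoro in place of chloro on an aromatic carbon, the same change as from compound 1 to compound 2, at the same place. The expected step is a 1.3-fold higher number from compound 3 to compound 4 (0.11 log units; within the scatter), set beside the unreadable step that the two limits leave unreadable from compound 1 to compound 2. It rests on compound 3 giving 93900 nM. That number already sits close to the limit of > 100000 nM in this assay, at which 2 of the 3 values shown sit, at which compound 1 and compound 2 sit. For compound 4 the expected value in this assay is 120000 nM, between 50000 nM and 300000 nM, with a high chance that only a limit is returned.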

Compound 4, concentration for 50% growth inhibition: 81800 nM
Compound 4: the middle estimate sits 1.5-fold (0.17 log units) above what was measured, and the stated range covers the measured number.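

Carrying the (sulfamoylamino)methyl in place of sulfamoylamino change from the chloro compounds to the fluoro compounds gives an at least 1.2-fold lower number from compound 2 to compound 4 (0.08 log units; that floor lies within the scatter) in this assay, and the comparison with the chloro pair stays open: the same change on two cores in this assay, an at least 1.0-fold lower number (0.02 log units; that floor lies within the scatter) from compound 1 to compound 3 and an at least 1.2-fold lower number (0.08 log units; that floor lies within the scatter) from compound 2 to compound 4; the limit leaves it open whether they differ. Both floors lie within the scatter, so the change is not shown to lower the number on either core, and it is not shown to act differently on the two, since each step starts from a limit and not a number: the limit of > 100000 nM in this assay, at which 2 of the 4 values shown sit. With the longer chain in place, fluoro in place of chloro gives a 1.1-fold lower number from compound 3 to compound 4 (0.06 log units; within the scatter), which is within the scatter, while the same change on the shorter chain cannot be read.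

The compounds shown leave open whether any change in this series gives a number well clear of the limit in this assay. A longer chain, an amine in place of the sulfamoylamino group, or a methoxy group in place of the halogen on the aromatic ring would each test this.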